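The compounds below may be only part of what the source reports. "The series", "measured", "known", "first", "only" and "open" are said of these compounds alone.

Measured compounds:
Compound 1, `CCCCCc1c(C(C)C)nc(C(C)C)c(CO)c1-c1ccc(C(C)C)cc1`: 34%
Compound 2, `CCCCCc1c(C(C)C)nc(C(C)C)c(CO)c1-c1ccc2c(c1)CCCC2`: 37%
Compound 3, `CCCCCc1c(C(C)C)nc(C(C)C)c(C)c1-c1ccccc1O`: 11%

All three numbers come from an assay on CHO cells for inhibition of Glucagon receptor (Homo sapiens), tested at 20 uM; on this read-out lower numbers stand for less inhibition and higher numbers for more inhibition at the one concentration tested (going by the name of the read-out). Compound 1 stands second highest of the three; compound 2 lies only a short distance higher, within the scatter, so the two cannot be ordered, while compound 3 lies far below compound 1, beyond the scatter. Going by the values given here, no pair of measured compounds differs in one place only, so no single step can be read off the measured set.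

Compound 4, `CCCCCc1c(C(C)C)nc(C(C)C)c(CO)c1-c1ccc(O)cc1`, is not yet measured in this assay. Its change from compound 1: hydroxy in place of isopropyl on an aromatic carbon. Among the compounds with values here, compound 3 is the only measured compound that carries a hydroxy on its aromatic ring, and in this assay compound 3 gives 11%, the lowest of the three, although it also differs from compound 1 in other places. The step from compound 1 to compound 4 is therefore expected to go down, by about a number 16 percentage points lower from compound 1 to compound 4 (beyond the scatter), beyond the scatter but on thin support. Compound 4 is expected to give 18%, within a range from 5% to 35%.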

Compound 4, a percentage reported as inhibition, at one concentration (the size of the read-out at that concentration, not a potency): 24%
For compound 4 the middle estimate is 6 percentage points below the measured one; low and high end bracket the measured number.
By their numbers in this assay, from the lowest: compound 3; then compounds 4, 1 and 2 (each within the scatter of the next, the first and the last beyond it).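

In this assay, hydroxy in place of isopropyl on the aromatic carbon para to a large group gives a number 10 percentage points lower from compound 1 to compound 4 (within the scatter). Going by these compounds alone, this is the first step that can be read at a single place, and it shows that this position accepts the exchange without a difference that can be separated from the scatter, although the hydroxy brings a hydrogen-bond donor and acceptor that the isopropyl lacks. Nothing measured here bears on the cause of this result.

Going by these compounds, whether an amine, a methoxy or a carboxylic acid on this same carbon would give a step beyond the scatter remains open. Also open, on these data alone, is whether the hydroxymethyl or the pentyl chain on the shared core can be exchanged for another group, such as a carboxylic acid or a longer chain, with as little consequence.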